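A few compounds are considered here, and "the series" means these few. Any claim that something is new, unique, unknown or untested is made for them only; others in the source may bear on it.

Measured compounds in this series:

compound 1, `Cn1nnnc1-c1ccccc1-c1ccc(CN2C(=O)[C@H](NC(=O)CC(C)(C)N)CCc3ccccc32)cc1` — 0.5 uM in a functional assay (Pituitary gland cell) with Rattus norvegicus as the target; a lower number here means that less compound is needed, a higher number that more compound is needed for the effect
compound 2, `CC(C)(N)CC(=O)N[C@@H]1CCc2ccccc2N(Cc2ccc(-c3ccccc3-c3nnn(CC(=O)O)n3)cc2)C1=O` — 0.2 uM in this assay

Among the measured compounds shown here, compound 1 stands highest of the two numbers so far; its nearest neighbour is compound 2, and the step of a 2.5-fold lower number from compound 1 to compound 2 (0.40 log units; beyond the scatter) is the only measured step in the set. That step exchanges one group on the tetrazole for another; the tetrazole itself stays in both compounds.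

Compound 3, `Cc1ccccc1-c1ccc(CN2C(=O)[C@H](NC(=O)CC(C)(C)N)CCc3ccccc32)cc1`, is not yet measured. Its difference from compound 1 is methyl in place of 1-methyl-1H-tetrazol-5-yl on an aromatic carbon. For the measured compounds named here, no measured pair bears directly on this change: the step from compound 1 to compound 2 varies what hangs on the tetrazole, whereas here the whole five-membered aromatic ring with four hetero atoms leaves and only a methyl remains on that aromatic carbon. Going by the values given here, the one measured step shows that this position responds beyond the scatter to a small change, which makes an unchanged number for the larger change unlikely. The step of a 10-fold higher number from compound 1 to compound 3 (1.00 log units; beyond the scatter) is therefore expected to run upward, towards a higher number, in this assay. Compound 3 is estimated at 5 uM in this assay, within the range 1 uM to 30 uM.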

Compound 3, concentration for half-maximal effect: 1 uM
Compound 3: middle estimate off by 5.0-fold (0.70 log units), on the high side; measured number inside the range.
By their numbers in this assay, from the lowest: compound 2; then compounds 1 and 3 (each within the scatter of the next).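

In this assay, the whole 1-methyl-1H-tetrazol-5-yl gives way to methyl on the aromatic carbon with a 2.0-fold higher number from compound 1 to compound 3 (0.30 log units; within the scatter) and nothing more, so at this place the numbers of compound 1 and compound 3 cannot be told apart, although the change removes a complete five-membered aromatic ring with 4 hetero atoms. The clear separation lies with compound 2 alone: a 5.0-fold higher number from compound 2 to compound 3 (0.70 log units; beyond the scatter) is beyond the scatter, as is a 2.5-fold lower number from compound 1 to compound 2 (0.40 log units; beyond the scatter), so among these three compounds the tetrazole carrying a methyl is not set apart from a plain methyl, while the tetrazole carrying the carboxymethyl group is. Nothing available here accounts for these numbers.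

Still open, going by these compounds, is whether a carboxylic acid placed directly on that aromatic carbon, with no tetrazole, would match compound 2 or fall with compound 1 and compound 3. Also open, on these data alone, is how the tetrazole responds to other groups in the same place, such as an amine, an ester of the carboxymethyl group or a longer chain ending in a carboxylic acid.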